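A few compounds are considered here, and "the series" means these few. Any claim that something is new, unique, unknown or untested is made for them only; others in the source may bear on it.

Measured compounds in this series:
- compound 1 `O[C@H]1CCc2ccccc2[C@@H]1n1ccnc1`: > 100 ug/mL
- compound 2 `O[C@H]1CCc2ccccc2[C@@H]1n1ccnn1`: 35.6 ug/mL
- compound 3 `O=[N+]([O-])c1cc(C(F)(F)F)ccc1O[C@H]1CCc2ccccc2[C@@H]1n1ccnc1`: 20.1 ug/mL

In an ADME assay on J774.A1 cells (Mus musculus) for cytotoxicity, read by MTT assay (a lower number here means that less compound is tolerated, a higher number that more compound is tolerated), compound 1 sits at > 100 ug/mL, which is a limit of the assay and not a number (the limit of > 100 ug/mL in this assay, at which 1 of the 3 values shown sits). Compound 2, with the azole exchanged, gives 35.6 ug/mL, and the step of an at least 2.8-fold lower number from compound 1 to compound 2 (0.44 log units; beyond the scatter) is beyond the scatter. Among the measured compounds shown here, compound 3 carries a substituted aryl group on the oxygen of the shared core and gives 20.1 ug/mL; no computed step is available between compound 1 and compound 3, so only the two values themselves can be set side by side.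

Compound 4 `Clc1cccc(CO[C@H]2CCc3ccccc3[C@@H]2n2ccnc2)c1` differs from compound 1 by 3-chlorobenzyl in place of hydrogen on an oxygen on a saturated carbon. For the measured compounds named here, the one measured step, from compound 1 to compound 2, changes the azole and not the oxygen, so it does not bear directly on this change. The nearest point of comparison is compound 3, where substitution on the same oxygen goes together with a number below the limit that compound 1 reaches. On that basis a lower number than for compound 1 is expected in this assay, though its size is uncertain because the reference for compound 1 is a limit (the limit of > 100 ug/mL in this assay, at which 1 of the 3 values shown sits). Compound 4 is estimated at 35 ug/mL, range 12 ug/mL to 100 ug/mL, which corresponds to an expected step of an at least 2.8-fold lower number from compound 1 to compound 4 (0.45 log units; beyond the scatter).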

Compound 4, half-maximal cytotoxic concentration: 15.5 ug/mL
Estimate against measurement, compound 4: 2.3-fold (0.35 log units) above, within the range that was stated.
By their numbers in this assay, from the lowest: compounds 4, 3 and 2 (each within the scatter of the next, the first and the last beyond it). At a limit, above all of these: compound 1.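

In this assay, the oxygen on a saturated carbon now has a step of its own: 3-chlorobenzyl in place of hydrogen, with the 1H-imidazol-1-yl group kept, gives an at least 6.4-fold lower number from compound 1 to compound 4 (0.80 log units; beyond the scatter). Compound 3, with its substituted aryl group on the same oxygen, gives 20.1 ug/mL and compound 4 gives 15.5 ug/mL; these two values lie within the scatter of each other, so for these two compounds the different groups on this oxygen read alike. The printed step gives only a minimum size because compound 1 stands at a limit: the limit of > 100 ug/mL in this assay, at which 1 of the 4 values shown sits.

On these data alone, it remains open whether any group on this oxygen goes with a number in this range, or whether that holds only for groups carrying an aromatic ring; a plain methyl, a longer alkyl chain, an unsubstituted benzyl or a chain ending in a carboxylic acid would separate these readings. Also open, as far as these compounds go, is whether 3-chlorobenzyl on the oxygen and 1H-1,2,3-triazol-1-yl in place of 1H-imidazol-1-yl add up when both stand on the shared core.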